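This account rests on a few compounds, and the source may have more. Where it says the series, first, only, none or still open, it means among the compounds named here.

Notes on the series. In an ADME assay on HEp-2 cells (Homo sapiens) for cytotoxicity, read by CCK-8 assay, with a stated time of 5 days (on this read-out lower numbers stand for higher toxicity in this test and higher numbers for lower toxicity in this test), compound 1 `CC(O)CNc1cc(N2CCc3ccccc3C2)nc2ccccc12` gives 89000 nM. Compound 2 `CS(=O)(=O)c1ccc2nc(N3CCCc4ccccc4C3)cc(NCCN)c2c1` gives 13000 nM in this assay. For compound 3 `Cc1ccc2nc(N3CCCc4ccc(F)cc4C3)cc(NCCN)c2c1` this assay reports only a limit, > 3200 nM, so where it stands on the scale is open; the evidence here is the limit of > 3200 nM in this assay, at which 1 of the 3 values shown sits. Going by the values given here, no two measured compounds differ in one place, so no measured step exists in this set. Compound 4 `Cc1ccc2nc(N3CCCc4ccc(F)cc4C3)cc(NCCN3CCNCC3)c2c1` differs from compound 3 by piperazin-1-yl in place of amino on a saturated chain carbon, two bonds along the chain from a nitrogen on an aromatic ring. Among the compounds with values here, with no measured step to rest on, the step expected from compound 3 to compound 4 in this assay is a step that the limit leaves unreadable from compound 3 to compound 4, with no direction beyond the scatter. Compound 4 is expected to give about 15000 nM in this assay, with a range from 4000 nM to 60000 nM.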

Compound 4, half-maximal cytotoxic concentration: 40000 nM
Compound 4: the middle estimate sits 2.7-fold (0.43 log units) below what was measured, within the range that was stated.
By their numbers in this assay, from the lowest: compound 2; then compound 4; then compound 1.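

No step can be read from compound 3 to compound 4 in this assay, because compound 3 carries only a limit: the limit of > 3200 nM in this assay, at which 1 of the 4 values shown sits.
In this assay the compounds shown leave open whether piperazin-1-yl in place of amino shifts the value at all.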